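A Further Methyl Where Every Value Is a Limit

The source may report more compounds than this note shows. Statements on the series, on what has been measured and on what is new or still open speak of the compounds shown alone.

Compound 1 `N#Cc1cc(=O)[nH]c(=O)n1[C@@H]1O[C@H](CO)[C@@H](O)[C@H]1O`: > 50000 nM
Compound 2 `Nc1cc(=O)[nH]c(=O)n1[C@@H]1O[C@H](CO)[C@@H](O)[C@H]1O`: > 50000 nM
Compound 3 `CNc1cc(=O)[nH]c(=O)n1[C@@H]1O[C@H](CO)[C@@H](O)[C@H]1O`: > 50000 nM

These results come from a functional assay on ML1 cells (Homo sapiens) for antiproliferative activity, read by WST assay, with a stated time of 3 days; on this read-out lower numbers stand for stronger inhibition and higher numbers for weaker inhibition. There compound 3 gives > 50000 nM, which is a limit and not a number. It has company: the limit of > 50000 nM in this assay, at which 3 of the 3 values shown sit. Compound 3 therefore shares its place with compound 1 and compound 2, and no number ranks the three.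

Compound 4 `CN(C)c1cc(=O)[nH]c(=O)n1[C@@H]1O[C@H](CO)[C@@H](O)[C@H]1O` differs from compound 3 in one place, methylamino to dimethylamino: methyl in place of hydrogen on a nitrogen on an aromatic ring. In words, this is methyl in place of hydrogen on a nitrogen on an aromatic ring.

Going by the values given here, the closest precedent is a step that the two limits leave unreadable from compound 2 to compound 3, which is the same kind of change. Two other measured steps replace the group at this same place, a step that the two limits leave unreadable from compound 1 to compound 2 and a step that the two limits leave unreadable from compound 1 to compound 3. None of the three has a size that can be read, so they offer no direction and no magnitude to carry over. The plain expectation is that compound 4 stays at the same limit in this assay, with no measurable gain.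

The expected change is a step that the limit leaves unreadable from compound 3 to compound 4. The estimate for compound 4 is 60000 nM, with an expected range from 25000 nM to 150000 nM.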

Compound 4, half-maximal inhibitory concentration: > 50000 nM
Compound 4 was reported as a limit (the forecaster's own chance of this, stated with the estimate: 90%); the middle value is on the limit's open side.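

In this assay compound 4 gives > 50000 nM, which is a limit and not a number. None of the steps linking compound 1, compound 2, compound 3 and compound 4 can be read, and all four sit together: the limit of > 50000 nM in this assay, at which 4 of the 4 values shown sit.

The compounds shown leave open whether any of the four differs from the others in this read-out, and whether any group at this place would give a readable value.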